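Ethoxy to Methylsulfonyl on the Compound 1 Core

The compounds below may be only part of what the source reports. "The series", "measured", "known", "first", "only" and "open" are said of these compounds alone.

Within the data shown here, compound 1 `CCOc1ccccc1OC(C)C1=NCCN1` gives 1320 nM in an assay on CHO cells for displacement of a labelled ligand from Alpha-2B adrenergic receptor (Homo sapiens) (a lower number here means a stronger inhibitor, a higher number a weaker inhibitor), the highest of the two numbers so far; compound 2 `CC(Oc1ccccc1OC1CC1)C1=NCCN1` gives 1050 nM, and the step of a 1.3-fold lower number from compound 1 to compound 2 (0.10 log units; within the scatter) stays within the scatter. Compound 3 `CC(Oc1ccccc1S(C)(=O)=O)C1=NCCN1` is not yet measured and differs from compound 1 by methylsulfonyl in place of ethoxy on an aromatic carbon. Among the measured compounds shown here, no measured step exchanges ethoxy for methylsulfonyl; the single step measured shows only that a change on this aromatic carbon can leave the number nearly unchanged. A step in this assay of uncertain direction is therefore expected, a 1.5-fold higher number from compound 1 to compound 3 (0.18 log units; within the scatter). For compound 3 the estimate is 2000 nM, ranging from 500 nM to 8000 nM.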

Compound 3, inhibition constant: 51300 nM
For compound 3 the middle estimate is 26-fold (1.41 log units) below the measured one; the measured number lies above the stated range.
By their numbers in this assay, from the lowest: compounds 2 and 1 (each within the scatter of the next); then compound 3.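

Methylsulfonyl in place of ethoxy gives a 39-fold higher number from compound 1 to compound 3 (1.59 log units; beyond the scatter) and in place of cyclopropyloxy gives a 49-fold higher number from compound 2 to compound 3 (1.69 log units; beyond the scatter) in this assay on this aromatic carbon. The position is therefore not indifferent to its substituent: the two oxygen-linked groups of compound 1 and compound 2 lie within the scatter of each other, whereas methylsulfonyl in compound 3 stands well apart from both. Nothing at hand bears on the reason for these steps.

Still open, going by these compounds, is whether an amine or a carboxylic acid on this carbon would give a number near compound 1 or near compound 3. Also open, on these data alone, is whether a longer alkoxy chain would stay close to ethoxy.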